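Taking the Methyl off Compound 2's Methoxy Group

This account rests on a few compounds, and the source may have more. Where it says the series, first, only, none or still open, it means among the compounds named here.

Measured compounds in a functional assay on HCT-15 cells (Homo sapiens) for inhibition, read by sulforhodamine B assay, with a stated time of 48 h; on this read-out higher numbers stand for weaker inhibition of growth and lower numbers for stronger inhibition of growth:
compound 1 (`O=C(Nc1cccc(-n2cc(-c3ccncc3)c(-c3ccc(Cl)c(O)c3)n2)c1)Nc1cccc(C(F)(F)F)c1`): compound 1 gives only a limit of this assay, > 32500 nM.
compound 2 (`COc1cc(-c2nn(-c3cccc(NC(=O)Nc4cc(C(F)(F)F)cc(C(F)(F)F)c4)c3)cc2-c2ccncc2)ccc1Cl`): compound 2 gives 1640 nM.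
compound 3 (`COc1cc(-c2nn(-c3cccc(NC(=O)Nc4cccc(C(F)(F)F)c4)c3)cc2-c2ccncc2)ccc1Cl`): compound 3 gives 5420 nM.

Compound 2 stands lowest of the two numbers given. Its nearest neighbour is reached by a 3.3-fold higher number from compound 2 to compound 3 (0.52 log units; beyond the scatter), a change of hydrogen in place of trifluoromethyl on an aromatic carbon.

Compound 4 (`O=C(Nc1cccc(-n2cc(-c3ccncc3)c(-c3ccc(Cl)c(O)c3)n2)c1)Nc1cc(C(F)(F)F)cc(C(F)(F)F)c1`) differs from compound 2 by hydrogen in place of methyl on an oxygen on an aromatic ring; read one bond further out, the methoxy becomes a hydroxy, so the 4-chloro-3-methoxyphenyl turns into a 4-chloro-3-hydroxyphenyl. Within the data shown here, one measured step bears on this change, run in the opposite direction: an at least 5.9-fold lower number from compound 1 to compound 3 (0.77 log units; beyond the scatter). As far as these compounds go, that step begins from a limit (the limit of > 32500 nM in this assay, at which 1 of the 3 values shown sits), so its true size is unknown.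

Reversing it on compound 2, an at least modest rise in the number is expected, and the result could again be only a limit. Compound 4 is therefore expected to give 12000 nM, estimated between 4000 nM and 36000 nM, which means an expected 7.3-fold higher number from compound 2 to compound 4 (0.86 log units; beyond the scatter).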

Compound 4, concentration for total growth inhibition: 3520 nM
Compound 4: the middle estimate sits 3.4-fold (0.53 log units) above what was measured; the whole stated range lies above it.
By their numbers in this assay, from the lowest: compound 2; then compounds 4 and 3 (each within the scatter of the next). At a limit, above all of these: compound 1.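

In this assay, changing the methoxy to a hydroxy gives a 2.1-fold higher number from compound 2 to compound 4 (0.33 log units; beyond the scatter), so on this core the hydroxy at this position still gives a full number rather than a limit. The same change differs in size between the two cores: the same change on two cores in this assay, an at least 5.9-fold lower number (0.77 log units; beyond the scatter) from compound 1 to compound 3 and a 2.1-fold lower number (0.33 log units; beyond the scatter) from compound 4 to compound 2, at least 2.7-fold (0.44 log units) apart, beyond the scatter of two such steps. Read from the other side, placing a trifluoromethyl on the hydroxy core gives an at least 9.2-fold lower number from compound 1 to compound 4 (0.96 log units; beyond the scatter), and this step also differs from its counterpart on the methoxy core: the same change on two cores in this assay, a 3.3-fold higher number (0.52 log units; beyond the scatter) from compound 2 to compound 3 and an at least 9.2-fold higher number (0.96 log units; beyond the scatter) from compound 4 to compound 1, at least 2.7-fold (0.44 log units) apart, beyond the scatter of two such steps.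

Compound 1 gives only a limit, > 32500 nM. As far as these compounds go, the true size of both steps that involve compound 1 therefore stays open, as does how an ethyl or a longer chain on this oxygen, or an amine in place of the hydroxy, would read on either core.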